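This account rests on a few compounds, and the source may have more. Where it says the series, first, only, none or still open, it means among the compounds named here.

Compound 1 `Cn1c(Cc2nn(C)c(=O)c3ccccc23)nnc1SCC(=O)Nc1ccc(Cl)cc1Cl` gives 22500 nM in an assay on 32D cells for inhibition of interleukin-15 (Mus musculus), read by resazurin assay, with stated times of 30 min and 2.5 days, in the presence of a further agent that is not named here; a lower number here means a stronger inhibitor, a higher number a weaker inhibitor.
Compound 2 `Cn1c(Cc2nn(CCCO[Si](C)(C)C(C)(C)C)c(=O)c3ccccc23)nnc1SCCCCCCCC(=O)Nc1ccc(Cl)cc1Cl` gives > 30000 nM in this assay.

The figure for compound 2 is a limit of this assay and not a measured number, as shown by the limit of > 30000 nM in this assay, at which 1 of the 2 values shown sits; compound 2 therefore stands at the weak end of what this assay can report. Compound 1 does return a number, and it too is a weak inhibitor.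

Compound 3 `Cn1c(Cc2nn(CCCO)c(=O)c3ccccc23)nnc1SCCCCCCCC(=O)Nc1ccc(Cl)cc1Cl` differs from compound 2 in one place: a hydrogen atom in place of a group of 7 heavy atoms (6 carbon, 1 silicon; no ring), on an oxygen on a saturated carbon. Among the compounds with values here, no measured pair of compounds shows this particular change, so its effect in this assay is not known from the data here. Since both measured compounds sit at or near the weak end, compound 3 is expected to stay weak as well, and the step of a number no higher from compound 2 to compound 3 (the limit leaves the size open) is expected to lie within the usual scatter rather than beyond it. For compound 3 the estimate in this assay is 30000 nM, with a likely range from 10000 nM to 100000 nM, and a real chance that only a limit is reported.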

Compound 3, half-maximal inhibitory concentration: > 30000 nM
Compound 3 gave a limit, no number; the forecaster's own chance of this, stated with the estimate: 55%; the middle value sits exactly at the limit.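

In this assay, within the data shown here, compound 2 and compound 3 both give only a limit, not a number, so no step between them can be read. The compounds shown leave open how strongly either one truly inhibits, and whether a hydrogen atom in place of the group of 7 heavy atoms changes that at all.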